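Cinnamamide quinazolines tested for cytotoxicity in HeLa cells

This account rests on a few compounds, and the source may have more. Where it says the series, first, only, none or still open, it means among the compounds named here.

Measured compounds:
compound 1, `COc1cc(/C=C/C(=O)Nc2cc3c(Nc4ccc(F)c(Cl)c4)ncnc3cc2O[C@H]2CCOC2)cc(OC)c1OC`, a functional assay on HeLa cells (Homo sapiens) for cytotoxicity, read by MTT assay, with a stated time of 72 h; a lower number here means a stronger inhibitor, a higher number a weaker inhibitor: 24500 nM
compound 2, `COc1cc2ncnc(Nc3ccc(F)c(Cl)c3)c2cc1NC(=O)/C=C/c1ccc(C#N)cc1`, this assay: "not determined" (no result reported)

Within the data shown here, compound 1 carries the single number in the set: in this assay compound 1 gives 24500 nM, a weak result, and it stands alone because in this assay compound 2 gives "not determined" (no result reported). Among the measured compounds shown here, no step between two measured compounds is available, so the size of any change can only be anticipated, not read from data.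

Compound 3, `O=C(/C=C/c1ccc(F)cc1Cl)Nc1cc2c(Nc3ccc(F)c(Cl)c3)ncnc2cc1O[C@H]1CCOC1`, is not yet measured. It differs from compound 1 in one place: 2-chloro-4-fluorophenyl in place of 3,4,5-trimethoxyphenyl on a double-bonded chain carbon bound to a double-bonded chain carbon

For the measured compounds named here, with a single weak value and no measured step to lean on, the account expects compound 3 to stay in the weak range, with the estimated step of a 1.2-fold lower number from compound 1 to compound 3 (0.09 log units; within the scatter) lying within the usual scatter of this assay. For compound 3 the estimated value in this assay is 20000 nM, within a range from 5000 nM to 80000 nM.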

Compound 3, half-maximal inhibitory concentration: 37500 nM
Beside the measured number, compound 3's estimate is 1.9-fold (0.27 log units) below it; measured number inside the range.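

In this assay, 2-chloro-4-fluorophenyl in place of 3,4,5-trimethoxyphenyl on a double-bonded chain carbon bound to a double-bonded chain carbon gives a 1.5-fold higher number from compound 1 to compound 3 (0.18 log units; within the scatter) and so leaves compound 1 and compound 3 indistinguishable. Among these compounds, this is the first reading at this position: a group of 8 heavy atoms with no hydrogen-bond acceptors takes the place of one with 12 heavy atoms and 3 hydrogen-bond acceptors, and both compounds remain in the weak range. No measured evidence offers an explanation for this result.

From the compounds shown here alone, whether any group at this place can move the number beyond the scatter remains open, for example a phenyl ring carrying an amine or a carboxylic acid. Compound 2, with no result reported, cannot help to settle this.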